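Mirror image of a series held at the limit

The compounds below may be only part of what the source reports. "The series", "measured", "known", "first", "only" and "open" are said of these compounds alone.

Measured in a physicochemical assay for metabolic stability, read by HPLC, with a stated time of 12 h, at pH 1.2 (a higher number here means that the compound lasts longer, a lower number that the compound disappears faster), as follows:
- compound 1 `O=C(O)[C@H](CO)NC(=O)[C@H]1C[C@H](O)CN1` gives > 12 h
- compound 2 `O=C(O)[C@@H](CO)NC(=O)[C@H]1C[C@H](O)CN1` gives > 12 h
- compound 3 `O=C(N[C@H](CO)C(=O)O)[C@@H]1C[C@H](O)CN1` gives > 12 h

Compound 3 stands only at a limit (> 12 h) and has no number. All three compounds share that one limit (the limit of > 12 h in this assay, at which 3 of the 3 values shown sit) and no order among them can be read. Compound 4 `O=C(O)[C@H](CO)NC(=O)[C@H]1C[C@@H](O)CN1` is the mirror image of compound 3 (the two compounds have the same atoms and bonds and differ only in configuration as drawn: 3 of 3 stereo elements differ (all stereocentres are inverted: mirror images); a stereocentre at a saturated chain carbon is drawn R in compound 3 and S in compound 4; a stereocentre at a saturated ring carbon is drawn S in compound 3 and R in compound 4; a stereocentre at a saturated ring carbon is drawn S in compound 3 and R in compound 4) with the same atoms and bonds. Going by the values given here, three measured steps bear on this, each a change of configuration only (a step that the two limits leave unreadable from compound 1 to compound 2; a step that the two limits leave unreadable from compound 1 to compound 3; a step that the two limits leave unreadable from compound 2 to compound 3) and none has a readable size. No step beyond the scatter is therefore expected in this assay and no direction can be named. The step expected here is (a step that the limit leaves unreadable from compound 3 to compound 4) on this estimate. Compound 4 is expected at 20 h within a range from 12 h to 40 h and will most likely be reported as a limit.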

Compound 4, half-life: > 12 h
Compound 4: only a limit was reported; the forecaster's own chance of this, stated with the estimate: 90%; the middle value is on the limit's open side.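

In this assay, going by these compounds alone, compound 4 gives > 12 h, which is a limit, so no step between it and compound 1, compound 2 or compound 3 can be read. The compounds shown leave open whether configuration changes the half-life at all.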